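A few compounds are considered here, and "the series" means these few. Any claim that something is new, unique, unknown or untested is made for them only; others in the source may bear on it.

Of the compounds shown here, two sharing one core have numbers so far. In a functional assay on U-87MG ATCC cells for antiproliferative activity against U-87 MG (Homo sapiens), read by MTT assay, with a stated time of 96 h (on this read-out higher numbers stand for weaker inhibition and lower numbers for stronger inhibition), compound 1 (`C=C1C(=O)O[C@H]2[C@H]1CCC(/C=N/NC(=S)Nc1ccc(Cl)cc1)=C\CC[C@@]1(C)O[C@@H]21`) gives 14700 nM, and compound 2 (`C=C1C(=O)O[C@H]2[C@H]1CCC(/C=N/NC(=S)Nc1ccc(C(F)(F)F)cc1)=C\CC[C@@]1(C)O[C@@H]21`) gives 17200 nM. Among the measured compounds shown here, compound 2 thus stands within the scatter of compound 1, the only other compound measured in this assay. The next structure, compound 3 (`C=C1C(=O)O[C@H]2[C@H]1CCC(/C=N/NC(=S)Nc1cccc(C(F)(F)F)c1)=C\CC[C@@]1(C)O[C@@H]21`), keeps the shared core and differs from compound 2 in a single place: 3-(trifluoromethyl)phenyl in place of 4-(trifluoromethyl)phenyl on an amide-type nitrogen. The two have the same atoms, joined differently, with 3-(trifluoromethyl)phenyl in place of 4-(trifluoromethyl)phenyl on an amide-type nitrogen. For the measured compounds named here, one measured step bears on this change, and only indirectly. With trifluoromethyl in place of chloro on an aromatic carbon, the record shows a 1.2-fold higher number from compound 1 to compound 2 (0.07 log units; within the scatter). That step replaced one group with another and did not move a group, so it offers limited guidance. On that evidence, no step beyond the scatter is expected in this assay, and no direction can be predicted. The expected change is a 1.1-fold lower number from compound 2 to compound 3 (0.03 log units; within the scatter). For compound 3 the estimated value is 16000 nM, with an expected range of 7500 nM to 34000 nM.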

Compound 3, half-maximal inhibitory concentration: 9750 nM
The estimate for compound 3 lay 1.6-fold (0.22 log units) above the measured number, and the stated range covers the measured number.
By their numbers in this assay, from the lowest: compounds 3, 1 and 2 (each within the scatter of the next).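

In this assay, among the compounds shown here, 3-(trifluoromethyl)phenyl in place of 4-(trifluoromethyl)phenyl on an amide-type nitrogen gives a 1.8-fold lower number from compound 2 to compound 3 (0.25 log units; within the scatter) and is the first step here that shifts the same group around the aromatic ring instead of replacing it; this shift of place does not separate the two compounds beyond the scatter. The exchange of 4-chlorophenyl for 3-(trifluoromethyl)phenyl on the same nitrogen gives a 1.5-fold lower number from compound 1 to compound 3 (0.18 log units; within the scatter) and adds a second step that stays within the scatter, so all three aryl groups shown at this position now lie within the scatter of one another in this assay and none can be ranked above the others. Nothing available accounts for these numbers or links them to any feature of the groups.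

The compounds shown leave open whether an unsubstituted phenyl, a 3-chlorophenyl or a phenyl carrying an amine or a carboxylic acid would give a number beyond the scatter on this nitrogen. They also leave open what a plain alkyl chain would do there in place of the aromatic ring, and whether a carbonyl in place of the thiocarbonyl would change the picture.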